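Trifluoromethoxy to phenoxy on the aryl-triazole series

A few compounds are considered here, and "the series" means these few. Any claim that something is new, unique, unknown or untested is made for them only; others in the source may bear on it.

The shared core is an aryl-triazole, seen in compound 1 `Nc1ccc(-c2cn(-c3ccc(OC(F)(F)F)cc3)nn2)cc1` and in compound 2 `COc1ccc(-c2cn(-c3ccc(OC(F)(F)F)cc3)nn2)cc1` and compound 3 `Oc1cc(O)cc(-c2cn(-c3ccc(OC(F)(F)F)cc3)nn2)c1`. In a functional assay on MDA-MB-231 cells (Homo sapiens) for cytotoxicity, read by MTT assay (a higher number here means a weaker inhibitor, a lower number a stronger inhibitor), compound 1 gives only a limit, > 10 nM; this is a boundary of the assay, not a number (the limit of > 10 nM in this assay, at which 1 of the 3 values shown sits). In this assay compound 2 gives 1000 nM. For compound 3 the read-out of this assay is again a limit, > 10000 nM, and not a number (the limit of > 10000 nM in this assay, at which 1 of the 3 values shown sits).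

Among the compounds with values here, the step of an at least 10-fold higher number from compound 2 to compound 3 (1.00 log units; beyond the scatter) is the only measured step with a readable size; it comes from exchanging the aryl group on the triazole carbon. The steps a step that the limit leaves unreadable from compound 1 to compound 2 and a step that the two limits leave unreadable from compound 1 to compound 3 cannot be sized because compound 1 stands at a limit.

Compound 4 `Nc1ccc(-c2cn(-c3ccc(Oc4ccccc4)cc3)nn2)cc1` is not yet measured. It differs from compound 1 by phenyl in place of trifluoromethyl on an oxygen on an aromatic ring. Within the data shown here, none of the measured steps touches this oxygen position; all three change the aryl group on the other side of the core, so nothing sizes this step. Compound 1 itself gives only a limit, which leaves the starting point open. The estimate for compound 4 in this assay is therefore 3000 nM, within 300 nM to 30000 nM, which is expected to mean a step that the limit leaves unreadable from compound 1 to compound 4 and carries wide uncertainty.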

Compound 4, half-maximal inhibitory concentration: > 10000 nM
Compound 4 gave a limit, no number; the forecaster's own chance of this, stated with the estimate: 40%; at least 3.3-fold (0.52 log units) between middle value and limit.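

In this assay compound 4 gives > 10000 nM, a limit and not a number. Within the data shown here, compound 1 also stands at a limit, and no step from compound 1 to compound 4 can be read. The compounds shown leave open whether phenoxy in place of trifluoromethoxy changes the read-out at all, and by how much.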